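Trimming the aromatic side group of compound 1 to a methyl

The source may hold more compounds than are shown below. What is called first, only, known or untested is meant among the compounds shown, and "the series" means these compounds.

Compound 1 `N#Cc1ccc(NC(=O)c2cc(-c3ccncc3)ccc2O)cc1` is the weaker of the two measured compounds: in a functional assay on KG-1 cells (Homo sapiens) for cytotoxicity, read by luminescence and CellTiter-Glo, with a stated time of 3 days (on this read-out lower numbers stand for stronger inhibition and higher numbers for weaker inhibition), compound 1 gives 7990 nM, the highest of the two numbers, while compound 2 `N#Cc1ccc(NC(=O)c2cc(Br)c(-c3ccccc3)cc2O)cc1` gives 850 nM, a step beyond the scatter. Compound 3 `Cc1ccc(O)c(C(=O)Nc2ccc(C#N)cc2)c1` differs from compound 1 by a single change, (methyl in place of pyridin-4-yl on an aromatic carbon). Among the measured compounds shown here, no measured pair shows this exact exchange. The change from compound 1 to compound 3 is expected to give a modest step toward a higher number, or none beyond the scatter, estimated as a 1.5-fold higher number from compound 1 to compound 3 (0.18 log units; within the scatter). Compound 3 is therefore expected to give about 12000 nM, with a likely range from 4000 nM to 40000 nM.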

Compound 3, half-maximal inhibitory concentration: 3370 nM
Estimate against measurement, compound 3: 3.6-fold (0.55 log units) above; measured number below the stated range.
By their numbers in this assay, from the lowest: compound 2; then compound 3; then compound 1.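

In this assay the exchange of pyridin-4-yl for methyl on this aromatic carbon, para to a hydroxy group, gives a 2.4-fold lower number from compound 1 to compound 3 (0.37 log units; beyond the scatter) and so shows that the six-membered aromatic ring is not needed here for the activity seen. At this position, the smaller of the two groups gives the lower number. Nothing measured on these compounds accounts for the step. The compounds shown leave open how an amine, a carboxylic acid or a longer chain at this carbon would compare with methyl.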